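The source may hold more compounds than are shown below. What is called first, only, known or untested is meant among the compounds shown, and "the series" means these compounds.

In an assay for inhibition of Caspase-8 (Homo sapiens) (on this read-out lower numbers stand for stronger inhibition and higher numbers for weaker inhibition), compound 2 `CCC(C(=O)N[C@@H](CC(=O)O)C(=O)CSCc1ccccc1)n1ccnc(NCc2cccs2)c1=O` gives 2090 nM, the lowest of the two numbers reported. Compound 3 `CCC(C(=O)N[C@@H](CC(=O)O)C(=O)CNCN1CCCC1)n1ccnc(NCc2nonc2C)c1=O` gives 6220 nM in this assay, a gap beyond the scatter; the two compounds differ in more than one place, so their values are only set side by side. Compound 1 `CCCCCCN(C)CNCC(=O)[C@H](CC(=O)O)NC(=O)C(CC)n1ccnc(NCc2nonc2C)c1=O` reaches only the limit of > 10000 nM in this assay. Among the compounds with values here, the single measured step, an at least 1.6-fold lower number from compound 1 to compound 3 (0.20 log units; that floor lies within the scatter), concerns the far end of the molecule and starts from the limit of > 10000 nM in this assay, at which 1 of the 3 values shown sits, so its size is known only as a floor. Compound 4 `CCC(C(=O)N[C@@H](CC(=O)O)C(=O)CSCc1ccccc1)n1ccnc(NCCCOC)c1=O` differs from compound 2 at the other end: 2-methoxyethyl in place of thiophen-2-yl on a saturated chain carbon bound to a nitrogen on an aromatic ring. Within the data shown here, no measured step alters this position, so the measured compounds do not fix the direction. The exchange of a ring for a short chain is nevertheless expected to give a step of a 2.2-fold higher number from compound 2 to compound 4 (0.33 log units; beyond the scatter) toward a higher number. Compound 4 is therefore estimated at 4500 nM, between 1500 nM and 15000 nM.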

Compound 4, half-maximal inhibitory concentration: 7650 nM
Estimate against measurement, compound 4: 1.7-fold (0.23 log units) below; low and high end bracket the measured number.
By their numbers in this assay, from the lowest: compound 2; then compounds 3 and 4 (each within the scatter of the next). At a limit, above all of these: compound 1.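

In this assay, the change on a saturated chain carbon bound to a nitrogen on an aromatic ring gives a 3.7-fold higher number from compound 2 to compound 4 (0.56 log units; beyond the scatter). Within the data shown here, the one earlier step concerned the far end of the molecule and started from a limit, whereas this one has a known size and direction, so this position also moves the read-out, with thiophen-2-yl on the side of the lower number. Nothing at hand accounts for the size of this step.

As far as these compounds go, the step is read only with the far end shared by compound 2 and compound 4, so whether it carries over to the amine-bearing far end of compound 3 remains open. Also open, from the compounds shown here alone, is how a phenyl or furan-2-yl ring would stand here, and with it whether the ring or its sulfur matters.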